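The compounds below may be only part of what the source reports. "The series", "measured", "known", "first", "only" and "open" are said of these compounds alone.

Working notes on the series. Compound 1, `CN1C[C@H]2C=C(c3cccnc3)C[C@H](C2)C1`, stands lowest of the three compounds measured in an in vitro functional assay on SH-EP1 cells for agonist activity at Neuronal acetylcholine receptor; alpha4/beta2 (Homo sapiens), read by FLIPR and calcium flux; a higher number here means a larger maximal response, a lower number a smaller maximal response: compound 1 gives 19%. Compound 2, `CC(C)Oc1cncc(C2=CC3CNCC(C2)C3)c1`, gives 75% in this assay, and compound 3, `COc1ccc(C2=CC3CC(C2)CN(C)C3)cn1`, gives 91%; both gaps from compound 1 lie beyond the scatter.

Compound 4, `C1=C(c2cccnc2)C[C@H]2CNC[C@@H]1C2`, differs from compound 1 by hydrogen in place of methyl on an amine nitrogen in a ring. Among the measured compounds shown here, no measured pair isolates this change: compound 2 carries hydrogen on the amine nitrogen in its ring and compound 3 carries methyl, yet each also differs from compound 1 elsewhere, so their numbers fix no step for it. For compound 4 in this assay a moderate upward step a number 21 percentage points higher from compound 1 to compound 4 (beyond the scatter) is expected, with a result within the scatter not excluded. The estimate for compound 4 is 40%, in a range from 15% to 75%.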

Compound 4, largest response reached (reported as percent of maximum), in percent of the reference or control that the assay uses: 114%
For compound 4 the middle estimate is 74 percentage points below the measured one, outside the stated range (above it).
By their numbers in this assay, from the lowest: compound 1; then compound 2; then compound 3; then compound 4.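

Hydrogen in place of methyl on an amine nitrogen in a ring can now be read as an isolated change: in this assay it gives a number 95 percentage points higher from compound 1 to compound 4 (beyond the scatter). The change removes one carbon, yet on the core of compound 1 the substituent on this nitrogen alone is enough to shift the maximal response by a large step. No measurement shown bears on the reason for the size of this step.

Going by these compounds, how an ethyl group on this nitrogen would compare stays open. Also open is whether the step carries over to compound 2 and compound 3, neither of which has a partner among the compounds shown that differs only on that nitrogen.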